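Swapping 4-formylphenyl for furan-3-yl in a cytotoxicity series

This account rests on a few compounds, and the source may have more. Where it says the series, first, only, none or still open, it means among the compounds named here.

Compound 1, `C=Cc1ccc(-c2cc(C)c3ncc(CSCc4ccccc4)n3c2)cc1`: in an ADME assay on HEL cells (Homo sapiens) for cytotoxicity, with a stated time of 3 days (a lower number here means that less compound is tolerated, a higher number that more compound is tolerated), compound 1 gives >= 100 ug/mL, which is a limit of the assay rather than a number.
Compound 2, `Cc1cc(-c2ccc(C=O)cc2)cn2c(CSCCc3ccccc3)cnc12`: in this assay compound 2 gives 100 ug/mL.
Compound 3, `Cc1cc(-c2ccc3[nH]ccc3c2)cn2c(CSCCc3ccccc3)cnc12`: in this assay compound 3 gives >= 20 ug/mL, again a limit rather than a number.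

Among the measured compounds shown here, compound 2 thus holds the only actual number among the three; the other two values are limits. The step from compound 2 to compound 3 puts 1H-indol-5-yl in place of 4-formylphenyl on an aromatic carbon, but its size, a step that the limit leaves unreadable from compound 2 to compound 3, cannot be read because of the limit of >= 20 ug/mL in this assay, at which 1 of the 3 values shown sits. Compound 1 in turn sits at the limit of >= 100 ug/mL in this assay, at which 1 of the 3 values shown sits, so no readable step is available from it either. Compound 4, `Cc1cc(-c2ccoc2)cn2c(CSCCc3ccccc3)cnc12`, differs from compound 2 by furan-3-yl in place of 4-formylphenyl on an aromatic carbon. For the measured compounds named here, no measured step bears readably on this change, so no movement beyond the scatter is expected; the expected step is no change at the digits printed from compound 2 to compound 4 (within the scatter). Compound 4 is therefore estimated to give 100 ug/mL in this assay, with a range from 50 ug/mL to 200 ug/mL.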

Compound 4, minimum cytotoxic concentration: > 4 ug/mL
Compound 4: no number, only a limit (the forecaster's own chance of this, stated with the estimate: 60%); the middle value does not contradict the limit.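

The result for compound 4 is a limit and not a number, so neither its step from compound 2 nor its step from compound 3 can be read: the limit of > 4 ug/mL in this assay, at which 1 of the 4 values shown sits. The compounds shown leave open whether furan-3-yl in place of 4-formylphenyl changes the tolerated concentration at all.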